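Thiosemicarbazone series: aryl hydrazone variation on the terpenoid core

The source may report more compounds than this note shows. Statements on the series, on what has been measured and on what is new or still open speak of the compounds shown alone.

Compound 1 `CC1=CC[C@@H]([C@@](C)(O)CCCC(C)(C)NC(=S)NN)CC1` carries the free thiosemicarbazide on the shared core. In a functional assay on OVCAR-3 cells (Homo sapiens) for cytotoxicity, read by sulforhodamine B assay (on this read-out higher numbers stand for weaker inhibition of growth and lower numbers for stronger inhibition of growth), compound 1 returns only a limit of the assay, > 100000 nM. Two hydrazones are measured. Compound 2 `CC1=CC[C@@H]([C@@](C)(O)CCCC(C)(C)NC(=S)N/N=C\c2ccc(C)cc2)CC1` gives 11800 nM in this assay. Compound 3 `CC1=CC[C@@H]([C@@](C)(O)CCCC(C)(C)NC(=S)N/N=C\c2ccccc2Cl)CC1` gives only a limit in this assay, > 100000 nM. Hence an at least 8.4-fold lower number from compound 1 to compound 2 (0.92 log units; beyond the scatter), whereas a step that the two limits leave unreadable from compound 1 to compound 3; between the hydrazones, an at least 8.4-fold higher number from compound 2 to compound 3 (0.92 log units; beyond the scatter). The whole set is read against (the limit of > 100000 nM in this assay, at which 2 of the 3 values shown sit).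

Compound 4 `CC1=CC[C@@H]([C@@](C)(O)CCCC(C)(C)NC(=S)N/N=C(/C)c2ccccc2)CC1` is not yet measured. It differs from compound 1 by a group of 9 heavy atoms (8 carbon, 1 nitrogen; one six-membered aromatic ring of carbon only) in place of one nitrogen atom, on an amide-type nitrogen: the amino group leaves and a group with one six-membered aromatic ring of carbon only, 1 double bond outside aromatic rings, 0 hydrogen-bond donors and 1 hydrogen-bond acceptor enters on the amide-type nitrogen next to the thiocarbonyl carbon. The bearing steps are the two hydrazone additions, one at least modest toward stronger inhibition and one unreadable. The expected result is an at least 3.3-fold lower number from compound 1 to compound 4 (0.52 log units; beyond the scatter), a modest drop. Compound 4 is expected at 30000 nM, its range running from 8000 nM to 120000 nM.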

Compound 4, concentration for total growth inhibition: 59500 nM
For compound 4 the middle estimate is 2.0-fold (0.30 log units) below the measured one, and the stated range covers the measured number.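

Against the free thiosemicarbazide and the 2-chlorophenyl hydrazone, the new reading in this assay gives only floors: an at least 1.6-fold lower number from compound 1 to compound 4 (0.22 log units; that floor lies within the scatter), and an at least 1.6-fold lower number from compound 3 to compound 4 (0.22 log units; that floor lies within the scatter), so neither step is established as a real gain. Among the two hydrazones with readable numbers, there is a 5.0-fold higher number from compound 2 to compound 4 (0.70 log units; beyond the scatter), which shows that the read-out on this assay is sensitive to the group entering on the amide-type nitrogen, even when the entering groups have the same heavy-atom count. Those two floors rest on limits and not on numbers: the limit of > 100000 nM in this assay, at which 2 of the 4 values shown sit.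

The step from compound 2 to compound 4 changes both the methyl on the aromatic ring and the methyl on the carbon with a double bond to nitrogen, and the two are not separated here. On these data alone, whether a 4-methoxyphenyl or a pyridine ring would hold or improve the reading remains open.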